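Ester and amide pair: aryl swap on the carbonyl carbon

A few compounds are considered here, and "the series" means these few. Any claim that something is new, unique, unknown or untested is made for them only; others in the source may bear on it.

Measured in an assay on NIH3T3 cells with Urotensin-2 receptor (Homo sapiens) as the target; a lower number here means that less compound is needed, a higher number that more compound is needed for the effect:
compound 1 `COc1ccc(C(=O)OC(CCN(C)C)c2ccc(Cl)cc2)cc1` gives 2190 nM
compound 2 `Cc1cccc(C(=O)OC(CCN(C)C)c2ccc(Cl)cc2)c1C` gives 1150 nM
compound 3 `COc1ccc(C(=O)NC(CCN(C)C)c2ccc(Cl)cc2)cc1` gives 1350 nM

Compound 1 and compound 3 carry the same aryl group on different cores; the difference between the two cores is not broken down here. Compound 2 differs from compound 1 by 2,3-dimethylphenyl in place of 4-methoxyphenyl on a carbonyl carbon, and the step of a 1.9-fold lower number from compound 1 to compound 2 (0.28 log units; within the scatter). Compound 4 `Cc1cccc(C(=O)NC(CCN(C)C)c2ccc(Cl)cc2)c1C` applies the same kind of change to compound 3: 2,3-dimethylphenyl in place of 4-methoxyphenyl on a carbonyl carbon. Around the place the cores differ: in compound 1 the carbonyl carbon's other neighbour is oxygen next to a carbonyl group, in compound 3 it is an amide-type nitrogen. Among the compounds with values here, no measured pair shows this kind of change on the amide core, so the expectation rests on a 1.9-fold lower number from compound 1 to compound 2 (0.28 log units; within the scatter) alone. For compound 4 the expected step is a 1.9-fold lower number from compound 3 to compound 4 (0.27 log units; within the scatter) in this assay. The estimate for compound 4 is 720 nM, between 300 nM and 1700 nM.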

Compound 4, half-maximal effective concentration: 3630 nM
Compound 4: middle estimate off by 5.0-fold (0.70 log units), on the low side, and the stated range ends below it.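

In this assay, 2,3-dimethylphenyl in place of 4-methoxyphenyl on a carbonyl carbon whose other neighbour is an amide-type nitrogen gives a 2.7-fold higher number from compound 3 to compound 4 (0.43 log units; beyond the scatter). In this series, the change does not carry over unchanged from the core of compound 1 to the core of compound 3: the same change on two cores in this assay, a 1.9-fold lower number (0.28 log units; within the scatter) from compound 1 to compound 2 and a 2.7-fold higher number (0.43 log units; beyond the scatter) from compound 3 to compound 4, 5.1-fold (0.71 log units) apart, beyond the scatter of two such steps. This rests on one pair per core, and the step on the core of compound 1 lies within the scatter, so it shows a dependence on the core for this one aryl swap only, with neither a general rule nor an explanation.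

Still open, on these data alone, is whether other aryl groups behave differently on the two cores, for example a plain phenyl group on the carbonyl carbon. A methyl group on the amide-type nitrogen would also test whether the amide hydrogen matters to this difference.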